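This account rests on a few compounds, and the source may have more. Where it says the series, first, only, none or still open, it means among the compounds named here.

In an ADME assay on L02 cells (Homo sapiens) for antiproliferative activity, read by MTT assay, with a stated time of 48 h (a lower number here means a stronger inhibitor, a higher number a weaker inhibitor), three compounds have been measured. Compound 1 `CCn1c(C(=O)Nc2ccc(OC(F)(F)F)cc2)ccc1C(CC)(CC)c1ccc(OCCC(O)(CC)CC)c(C)c1` gives > 50000 nM, which is a limit and not a number. Compound 2 `CCn1c(C(=O)Nc2cccc(C(F)(F)F)c2)ccc1C(CC)(CC)c1ccc(OCCC(O)(CC)CC)c(C)c1` gives > 50000 nM, again a limit. Compound 3 `CCC(C)C(CO)NC(=O)c1ccc(C(CC)(CC)c2ccc(OCCC(O)(CC)CC)c(C)c2)n1CC` gives > 50000 nM, also a limit. Compound 3 therefore has no rank among the others, and all that is shown is the limit of > 50000 nM in this assay, at which 3 of the 3 values shown sit.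

Compound 4 `CCn1c(C(=O)NC(C)CO)ccc1C(CC)(CC)c1ccc(OCCC(O)(CC)CC)c(C)c1` departs from compound 3 in one place: methyl in place of sec-butyl on a saturated chain carbon bound to an amide-type nitrogen and a saturated chain carbon. The group 1-(hydroxymethyl)-2-methylbutyl thus becomes 1-(hydroxymethyl)ethyl. Three measured steps change the group on the amide-type nitrogen: a step that the two limits leave unreadable from compound 1 to compound 2, a step that the two limits leave unreadable from compound 1 to compound 3 and a step that the two limits leave unreadable from compound 2 to compound 3. None of them has a readable size, so they offer no measured size to carry over. No step beyond the scatter is expected in this assay, and no direction can be named. The estimated step is a step that the limit leaves unreadable from compound 3 to compound 4. For compound 4 the estimated value is 60000 nM, with an expected range from 25000 nM to 150000 nM.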

Compound 4, half-maximal inhibitory concentration: 4840 nM
The estimate for compound 4 lay 12-fold (1.09 log units) above the measured number; the measured number lies below the stated range.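

Among the compounds shown here, replacing sec-butyl with methyl on a saturated chain carbon bound to an amide-type nitrogen and a saturated chain carbon gives an at least 10-fold lower number from compound 3 to compound 4 (1.01 log units; beyond the scatter), so this position can carry a readable change, which none of the earlier steps could show. The same 1-(hydroxymethyl)ethyl group also reads against the two aryl groups on the amide-type nitrogen, with an at least 10-fold lower number from compound 2 to compound 4 (1.01 log units; beyond the scatter) and an at least 10-fold lower number from compound 1 to compound 4 (1.01 log units; beyond the scatter). In this assay, compound 4 is the only compound shown with a number rather than a limit: the limit of > 50000 nM in this assay, at which 3 of the 4 values shown sit.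

On these data alone, whether a group of intermediate size, such as ethyl or isopropyl, would keep this lower number remains open. Also open is what the hydroxymethyl contributes, since the compounds shown offer no methoxymethyl or aminomethyl group in its place.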